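The source may report more compounds than this note shows. Statements on the series, on what has been measured and on what is new or still open speak of the compounds shown alone.

The measured compounds in a functional assay on PC-9 cells (Homo sapiens) for inhibition, read by MTT assay, with a stated time of 72 h; on this read-out higher numbers stand for weaker inhibition and lower numbers for stronger inhibition:
Compound 1 `Cc1cc(Nc2cc(-c3ccccc3)[nH]n2)n2nc(SCCc3ccccc3)nc2n1` gives 4930 nM.
Compound 2 `Cc1cc(Nc2cc(-c3ccccc3)[nH]n2)n2nc(SCc3ccc([N+](=O)[O-])cc3)nc2n1` gives 7980 nM.
Compound 3 `COc1ccc(CSc2nc3nc(C)cc(Nc4cc(-c5ccccc5)[nH]n4)n3n2)cc1` gives 8110 nM.

Among these three numbers compound 1 stands lowest, but its nearest neighbour is compound 2, with a 1.6-fold higher number from compound 1 to compound 2 (0.21 log units; within the scatter), and its furthest is compound 3, with a 1.6-fold higher number from compound 1 to compound 3 (0.22 log units; within the scatter); both steps sit within the scatter, so the three compounds are not separated on this read-out. Between the other two the difference is a 1.0-fold higher number from compound 2 to compound 3 (0.01 log units; within the scatter).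

The unmeasured compound 4 `Cc1cc(Nc2cc(-c3ccccc3)[nH]n2)n2nc(SCc3csc4ccccc34)nc2n1` departs from compound 1 at the same place as the two measured steps: 1-benzothiophen-3-yl in place of benzyl on a saturated chain carbon bound to a sulfur. The two steps that bear on it, from compound 1 to compound 2 and from compound 1 to compound 3, each replace the benzyl by another aromatic group on the saturated chain carbon bound to a sulfur, and neither moved the number beyond the scatter. The entering 1-benzothiophen-3-yl adds a five-membered aromatic ring with 1 hetero atom fused to the six-membered aromatic ring of carbon only, and the data hold nothing that shows what such a larger group does here. The expected step is therefore small, if anything toward a slightly higher number: a 1.3-fold higher number from compound 1 to compound 4 (0.12 log units; within the scatter). For compound 4 the estimate in this assay is 6500 nM, within a range of 2500 nM to 17000 nM.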

Compound 4, half-maximal inhibitory concentration: 4420 nM
Compound 4: middle estimate off by 1.5-fold (0.17 log units), on the high side; the range from low to high includes it.
By their numbers in this assay, from the lowest: compounds 4, 1, 2 and 3 (each within the scatter of the next).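

In this assay, among the compounds shown here, the earlier compounds carried only a single six-membered aromatic ring on the saturated chain carbon bound to a sulfur, whereas 1-benzothiophen-3-yl adds a five-membered aromatic ring with 1 hetero atom fused to that ring, and the number stays within the scatter of all three earlier compounds (a 1.1-fold lower number from compound 1 to compound 4 (0.05 log units; within the scatter); a 1.8-fold lower number from compound 3 to compound 4 (0.26 log units; within the scatter); a 1.8-fold lower number from compound 2 to compound 4 (0.26 log units; within the scatter)). The larger fused group therefore separates from neither the benzyl of compound 1 nor the 4-nitrophenyl of compound 2 nor the 4-methoxyphenyl of compound 3, so all four compounds remain unseparated on this read-out, and this position tolerates the two-ring group without any measurable change. No separate evidence is available that would account for these four numbers staying together.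

All four groups at this position are aromatic and uncharged, so the compounds shown leave open whether an amine or a carboxylic acid there, or a chain longer than phenethyl, would move the number beyond the scatter. They also leave open whether any change to the shared core would do more than these changes at the sulfur-bound chain.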